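The source may hold more compounds than are shown below. What is called first, only, known or untested is meant among the compounds shown, and "the series" means these compounds.

Measured so far in a functional assay on MOLT-4 cells (Homo sapiens) for antiproliferative activity, with a stated time of 48 h; a higher number here means a weaker inhibitor, a lower number a stronger inhibitor: compound 1 `C=C(Br)C(=O)Nc1ccc(C(=O)/C=C/c2ccc(OC)cc2)cc1` gives 610 nM; compound 2 `C=C(Br)C(=O)Nc1ccc(C(=O)/C=C/c2ccc(OC)cc2OC)cc1` gives 1500 nM; compound 3 `COc1ccccc1/C=C/C(=O)c1ccc(N)cc1` gives 8300 nM.

In this assay compound 1 carries the lowest number and compound 3 the highest. Among the compounds with values here, the one single-point step in the set, a 2.5-fold higher number from compound 1 to compound 2 (0.39 log units; beyond the scatter), accompanies (methoxy in place of hydrogen on an aromatic carbon). The difference between the cores of compound 3 and compound 1 is not broken down here.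

Compound 4 `COc1cccc(/C=C/C(=O)c2ccc(N)cc2)c1OC` is not yet measured. It differs from compound 3 by methoxy in place of hydrogen on an aromatic carbon, the same kind of change as that from compound 1 to compound 2, though the surroundings differ: there the entering group was ortho to a large group and meta to a methoxy group, here it is ortho to a methoxy group and meta to a large group. Resting on a 2.5-fold higher number from compound 1 to compound 2 (0.39 log units; beyond the scatter), a comparable step of a 1.9-fold higher number from compound 3 to compound 4 (0.29 log units; within the scatter) is expected. Compound 4 is estimated at 16000 nM, with a range from 6000 nM to 45000 nM.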

Compound 4, half-maximal inhibitory concentration: 8500 nM
Beside the measured number, compound 4's estimate is 1.9-fold (0.27 log units) above it; the range from low to high includes it.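

In this assay, methoxy in place of hydrogen on an aromatic carbon gives a 1.0-fold higher number from compound 3 to compound 4 (0.01 log units; within the scatter), so on this core the two numbers stand within the scatter of each other. Set beside the earlier step, the two cores cannot be told apart for this change: the same change on two cores in this assay, a 2.5-fold higher number (0.39 log units; beyond the scatter) from compound 1 to compound 2 and a 1.0-fold higher number (0.01 log units; within the scatter) from compound 3 to compound 4, 2.4-fold (0.38 log units) apart, within the scatter of two such steps

Within the data shown here, this does not show that the step has one fixed size on both cores: only two pairs are at hand, and the entering group has different surroundings in each.

Still open, going by these compounds, is whether a hydroxy group or a chlorine atom in place of that hydrogen would behave alike on both cores. Also open, on these data alone, is what a methoxy group ortho to a methoxy group and meta to a large group would do on the core of compound 1.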